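Methyl for Hydrogen on the Ester Chain of Compound 3

The compounds below may be only part of what the source reports. "The series", "measured", "known", "first", "only" and "open" are said of these compounds alone.

Compound 1 `CCOC(=O)C(C)Oc1ccc(NC(=O)CSc2ccc3ccccc3c2)cc1`: 28%
Compound 2 `CCOC(=O)C(C)Oc1ccc(NC(=O)COc2ccccc2Cl)cc1`: 26%
Compound 3 `CCOC(=O)C(C)Oc1ccc(NC(=O)COc2ccc3ccccc3c2)cc1`: 25%

In a functional assay for inhibition, read by spectrophotometry, tested at 200 ug/mL (on this read-out lower numbers stand for less inhibition and higher numbers for more inhibition at the one concentration tested (going by the name of the read-out)), compound 3 holds the lowest of the three numbers, yet both its nearest neighbour, compound 2, and the furthest, compound 1, lie within the scatter of it, so the three compounds cannot be placed in any order. Compound 4 `CCOC(=O)C(C)(C)Oc1ccc(NC(=O)COc2ccc3ccccc3c2)cc1` is not yet measured in this assay and differs from compound 3 by methyl in place of hydrogen on a saturated chain carbon bound to a carbonyl carbon, an oxygen on an aromatic ring and a saturated chain carbon. Going by the values given here, no pair of measured compounds shows what this change does, so the expected step of no change at the digits printed from compound 3 to compound 4 (within the scatter) is none beyond the scatter. Compound 4 is therefore expected to give about 25% in this assay, with a range from 14% to 38%.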

Compound 4, a percentage reported as inhibition, at one concentration (the size of the read-out at that concentration, not a potency): 22%
Compound 4: the middle estimate sits 3 percentage points above what was measured, and the stated range covers the measured number.
By their numbers in this assay, from the lowest: compounds 4, 3, 2 and 1 (each within the scatter of the next).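

In this assay the methyl in place of hydrogen on this saturated chain carbon, which turns 1-(ethoxycarbonyl)ethoxy into 1-(ethoxycarbonyl)-1-methylethoxy, gives a number 3 percentage points lower from compound 3 to compound 4 (within the scatter) and so no change that can be told from the scatter. This position therefore takes the added methyl without a readable effect on the number. No available evidence bears on this result. On these data alone, whether a carboxylic acid in place of the ethyl ester, or a longer chain on this carbon, would move the number beyond the scatter remains open.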